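The compounds below may be only part of what the source reports. "The series", "measured", "known", "first", "only" and "open" are said of these compounds alone.

Measured in a functional assay on A549 cells (Homo sapiens) for inhibition; on this read-out higher numbers stand for weaker inhibition and lower numbers for stronger inhibition:

- compound 1 `CCN(CC)CCNC(=O)CC(CC(=O)NC1Cc2ccccc2C1)c1ccc(Cl)cc1`: 48600 nM
- compound 2 `O=C(CC(CC(=O)NC1Cc2ccccc2C1)c1ccc(Cl)cc1)NCCN1CCCC1`: 50900 nM
- compound 3 `O=C(CC(CC(=O)NC1Cc2ccccc2C1)c1ccccc1)NCCN1CCCC1`: > 100000 nM, a limit of the assay

For the measured compounds named here, compound 2 stands level with the only other number, the step being a 1.0-fold higher number from compound 1 to compound 2 (0.02 log units; within the scatter). Compound 4 `CCN(C(=O)CC(CC(=O)NCCN1CCCC1)c1ccc(Cl)cc1)C1Cc2ccccc2C1` has ethyl in place of hydrogen on an amide-type nitrogen. Going by the values given here, no measured step touches that nitrogen, so the evidence is indirect. The two steps elsewhere on the structure are a 1.0-fold higher number from compound 1 to compound 2 (0.02 log units; within the scatter) and an at least 1.9-fold higher number from compound 2 to compound 3 (0.29 log units; that floor lies within the scatter), and neither is shown to lie beyond the scatter. In this assay the expected step is a 1.0-fold lower number from compound 2 to compound 4 (0.01 log units; within the scatter), so no change beyond the scatter is expected. For compound 4 the estimate is 50000 nM, with an expected range of 20000 nM to 100000 nM.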

Compound 4, half-maximal inhibitory concentration: 22600 nM
Estimate against measurement, compound 4: 2.2-fold (0.34 log units) above; the range from low to high includes it.
By their numbers in this assay, from the lowest: compound 4; then compounds 1 and 2 (each within the scatter of the next). At a limit, above all of these: compound 3.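

On the amide-type nitrogen whose other neighbours are a carbonyl carbon and a saturated ring carbon, ethyl in place of hydrogen gives the only step in this assay shown to lie beyond the scatter: a 2.3-fold lower number from compound 2 to compound 4 (0.35 log units; beyond the scatter). The amide hydrogen is therefore not needed for inhibition on this read-out, and the gain with ethyl is modest. Nothing at hand accounts for this step.

Going by these compounds, whether methyl, propyl or a longer chain on this nitrogen moves the number further remains open. Also open, on these data alone, is whether ethyl gives a similar step with the diethylamino group of compound 1.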